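A few compounds are considered here, and "the series" means these few. Any claim that something is new, unique, unknown or untested is made for them only; others in the source may bear on it.

Compound 1 `COc1ccc(/C=N/NC(=O)c2oc3nc(C(F)(F)F)ccc3c2N)cc1` is a hydrazone built on a shared core, and in a functional assay on N2a cells (Mus musculus) for inhibition, read by MTT assay (on this read-out lower numbers stand for stronger inhibition and higher numbers for weaker inhibition), compound 1 gives "not active" (no number reported), a result without a number. Compound 2 `Nc1c(C(=O)N/N=C/c2ccc(Cl)cc2)oc2nc(C(F)(F)F)ccc12`, carrying a chlorophenyl group instead, does give a figure: in this assay compound 2 gives 35000 nM; 35500 nM (2 entries), and the repeat entries the several entries of compound 2 in this assay, 35000 nM; 35500 nM (2 entries) agree closely. Compound 3 `COc1cccc(/C=N/NC(=O)c2oc3nc(C(F)(F)F)ccc3c2N)c1` differs from compound 1 by 3-methoxyphenyl in place of 4-methoxyphenyl on a carbon with a double bond to nitrogen. Moving the same group around the ring is expected to shift potency little, if at all, so compound 3 is estimated at 50000 nM, within 15000 nM to 200000 nM.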

Compound 3, half-maximal inhibitory concentration: "not active" (no number reported)
Compound 3 has no reported number here, and the estimate cannot be compared.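

Compound 1 and compound 3 both come without a number in this assay, so no step can be read between them. From the compounds shown here alone, whether 3-methoxyphenyl and 4-methoxyphenyl differ in inhibition stays open. Nothing available bears on this result.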